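Branched Groups on the Aromatic Nitrogen

The source may report more compounds than this note shows. Statements on the series, on what has been measured and on what is new or still open speak of the compounds shown alone.

Compound 1 `C/C(=C\C(=O)Nc1ccccc1OCCCC(=O)O)c1ccc2c(ccn2C)c1` gives 780 nM in an assay on Prostate gland for inhibition of steroid 5-alpha-reductase (Rattus norvegicus); a higher number here means a weaker inhibitor, a lower number a stronger inhibitor.
Compound 2 `CCCCC(CC)n1ccc2cc(/C(C)=C/C(=O)Nc3ccccc3OCCCC(=O)O)ccc21` gives 7.1 nM in this assay.
Compound 3 `C/C(=C\C(=O)Nc1ccccc1OCCCC(=O)O)c1ccc2c(ccn2C(C(C)C)C(C)C)c1` gives 14 nM in this assay.

Compound 3 stands second highest of the three numbers; its nearest neighbour is compound 2, a gap within the scatter, while the step of a 56-fold lower number from compound 1 to compound 3 (1.75 log units; beyond the scatter) is large. Compound 4 `C/C(=C\C(=O)Nc1ccccc1OCCCC(=O)O)c1ccc2c(ccn2C(C)c2ccccc2)c1` differs from compound 3 in one place: 1-phenylethyl in place of 1-isopropyl-2-methylpropyl on an aromatic nitrogen. Among the compounds with values here, the steps that bear on this are a 110-fold lower number from compound 1 to compound 2 (2.04 log units; beyond the scatter) and a 56-fold lower number from compound 1 to compound 3 (1.75 log units; beyond the scatter), both large and both replacing methyl with a branched group, whereas a 2.0-fold higher number from compound 2 to compound 3 (0.29 log units; within the scatter) shows that exchanging one branched group for another gives numbers within the scatter. With a branched group again at that place, compound 4 is expected to stay close to compound 3, the expected step being a 1.1-fold higher number from compound 3 to compound 4 (0.03 log units; within the scatter). The estimate for compound 4 is 15 nM, within 5 nM to 50 nM.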

Compound 4, half-maximal inhibitory concentration: 19 nM
Compound 4: the middle estimate sits 1.3-fold (0.10 log units) below what was measured; the measured number falls inside the stated range.
By their numbers in this assay, from the lowest: compounds 2, 3 and 4 (each within the scatter of the next, the first and the last beyond it); then compound 1.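

The 1-phenylethyl group puts a six-membered aromatic ring on the aromatic nitrogen, the first ring at this place among these compounds, and a 1.4-fold higher number from compound 3 to compound 4 (0.13 log units; within the scatter) shows that it can replace the ring-free 1-isopropyl-2-methylpropyl group without a change beyond the scatter. The ring does not match 1-ethylpentyl, with a 2.7-fold higher number from compound 2 to compound 4 (0.43 log units; beyond the scatter) as a modest step, yet a 41-fold lower number from compound 1 to compound 4 (1.61 log units; beyond the scatter) shows a large gain over methyl. Nothing available here explains these differences.

Still open, going by these compounds, is how an unbranched chain such as pentyl, a benzyl group or a chain ending in an amine would fare on this nitrogen.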